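A few compounds are considered here, and "the series" means these few. Any claim that something is new, unique, unknown or untested is made for them only; others in the source may bear on it.

In a functional assay on MKN-45 cells (Homo sapiens) for inhibition, read by MTT assay, with a stated time of 72 h (on this read-out higher numbers stand for weaker inhibition and lower numbers for stronger inhibition), compound 1 `COc1cc2c(Oc3ccc(NC(=O)c4nn(-c5ccccc5OC(F)(F)F)c(=O)cc4C)cc3F)ccnc2cc1OCCCN1CCN(C)CC1` gives 100 nM, compound 2 `COc1cc2c(Oc3ccc(NC(=O)c4nn(-c5cccc(F)c5)c(=O)cc4C)cc3F)ccnc2cc1OCCCN1CCN(C)CC1` gives 120 nM, and compound 3 `COc1cc2c(Oc3ccc(NC(=O)c4nn(-c5ccc(Cl)cc5)c(=O)cc4C)cc3F)ccnc2cc1OCCCN1CCN(C)CC1` gives 40 nM. Compound 3 stands lowest of the three: the steps of a 2.5-fold lower number from compound 1 to compound 3 (0.40 log units; beyond the scatter) and a 3.0-fold lower number from compound 2 to compound 3 (0.48 log units; beyond the scatter) both lie beyond the scatter, while the step of a 1.2-fold higher number from compound 1 to compound 2 (0.08 log units; within the scatter) does not. Compound 4 `COc1cc2c(Oc3ccc(NC(=O)c4nn(-c5ccc(F)c(F)c5)c(=O)cc4C)cc3F)ccnc2cc1OCCCN1CCN(C)CC1` has not yet been measured in this assay. The change from compound 3 to compound 4 is 3,4-difluorophenyl in place of 4-chlorophenyl on an aromatic nitrogen. Within the data shown here, two measured steps bear on it, each swapping the ring on the aromatic nitrogen: a 3.0-fold lower number from compound 2 to compound 3 (0.48 log units; beyond the scatter) and a 2.5-fold lower number from compound 1 to compound 3 (0.40 log units; beyond the scatter). Compound 2, whose ring carries fluorine, gives a higher number than compound 3 with its 4-chlorophenyl, and the incoming ring of compound 4 again carries fluorine rather than chlorine. Compound 4 is therefore expected to show a modest rise in the number, estimated as a 1.8-fold higher number from compound 3 to compound 4 (0.24 log units; within the scatter). In this assay compound 4 is expected to give about 70 nM, within a range from 35 nM to 150 nM.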

Compound 4, half-maximal inhibitory concentration: 120 nM
The estimate for compound 4 lay 1.7-fold (0.23 log units) below the measured number; the measured number falls inside the stated range.
By their numbers in this assay, from the lowest: compound 3; then compounds 1, 2 and 4 (each within the scatter of the next).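

Adding a second fluorine to the ring, going from 3-fluorophenyl to 3,4-difluorophenyl, leaves the result in this assay unchanged (no change at the digits printed from compound 2 to compound 4 (within the scatter)). The 4-chlorophenyl ring of compound 3 now stands apart from the 3,4-difluorophenyl ring as well (a 3.0-fold higher number from compound 3 to compound 4 (0.48 log units; beyond the scatter)), while the 2-(trifluoromethoxy)phenyl ring gives a result within the scatter of the 3,4-difluorophenyl ring (a 1.2-fold higher number from compound 1 to compound 4 (0.08 log units; within the scatter)), so among these four rings only the 4-chlorophenyl gives a distinctly lower number. No measurement shown here explains why this ring differs from the others.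

As far as these compounds go, it remains open whether the lower number follows the chlorine itself or the place it occupies on the ring. A 4-fluorophenyl ring and a 3-chlorophenyl ring would separate these two readings, and a 4-bromophenyl ring would show whether another heavier halogen behaves like chlorine.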